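This account rests on a few compounds, and the source may have more. Where it says the series, first, only, none or still open, it means among the compounds named here.

Measured so far in a functional assay on P388 cells (Mus musculus) for inhibition; a lower number here means a stronger inhibitor, a higher number a weaker inhibitor: compound 1 `O=C1/C(=C/c2ccccc2F)CCc2ccccc21` gives 21800 nM; compound 2 `O=C1/C(=C/c2ccccc2[N+](=O)[O-])CCc2ccccc21` gives 12600 nM.

Compound 2 holds the lower of the two numbers, but the gap between the two is only a 1.7-fold lower number from compound 1 to compound 2 (0.24 log units; within the scatter), which is within the scatter, so the two compounds cannot be told apart on these data.

Compound 3 `Cc1ccccc1/C=C1\CCc2ccccc2C1=O` is not yet measured. It differs from compound 2 in one place: methyl in place of nitro on an aromatic carbon. For the measured compounds named here, the only measured step available, a 1.7-fold lower number from compound 1 to compound 2 (0.24 log units; within the scatter), also swapped one small group for another at the same aromatic carbon of the shared core, and it stayed within the scatter. That step does not cover the exchange of nitro for methyl itself, so it gives only an indirect guide. With no measured change in this assay beyond the scatter from a swap at this position, the expectation for compound 3 is a step of about a 1.3-fold higher number from compound 2 to compound 3 (0.10 log units; within the scatter) from compound 2, that is, no change beyond the scatter in either direction. Compound 3 is therefore estimated at 16000 nM in this assay, with a likely range from 6000 nM to 45000 nM.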

Compound 3, half-maximal inhibitory concentration: 17700 nM
Compound 3: the middle estimate sits 1.1-fold (0.04 log units) below what was measured; the measured number falls inside the stated range.
By their numbers in this assay, from the lowest: compounds 2, 3 and 1 (each within the scatter of the next).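

In this assay the step with methyl in place of nitro on this aromatic carbon, ortho to a large group, is a 1.4-fold higher number from compound 2 to compound 3 (0.15 log units; within the scatter) and the step with methyl in place of fluoro is a 1.2-fold lower number from compound 1 to compound 3 (0.09 log units; within the scatter) so all three pairs among these compounds now lie within the scatter. Until now only fluoro and nitro could be compared here, whereas methyl adds a group of carbon alone with no hydrogen-bond acceptors, against the two that nitro carries, and even this exchange leaves the number in this assay within the scatter. Nothing available explains why these three groups read alike in this assay.

Fluoro, nitro and methyl are the only groups shown at this position, so it remains open whether an amine, a carboxylic acid or a longer chain on the same carbon would move the number beyond the scatter. On these data alone, it also remains open whether any of these three groups would read the same way when placed on a different carbon of that aromatic ring.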